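Extending the Hydroxycarbamoyl Chain of Compound 2

The source may hold more compounds than are shown below. What is called first, only, known or untested is meant among the compounds shown, and "the series" means these compounds.

In a functional assay on HEL cells (Homo sapiens) for inhibition, read by MTT assay, with a stated time of 48 h (a higher number here means a weaker inhibitor, a lower number a stronger inhibitor), compound 1 (`O=C(CCCCCCCOc1cccc(-c2nc3ccc(-c4nc5ccccc5[nH]4)cc3[nH]2)c1)NO`) gives 2300 nM while compound 2 (`O=C(CCCCCCOc1cccc(-c2nc3ccccc3[nH]2)c1)NO`) gives 20 nM and so holds the lower of the two numbers, a gap well beyond the usual scatter. These two compounds differ in more than one place, so their gap cannot be tied to any single change.

Compound 3 (`O=C(CCCCCCCOc1cccc(-c2nc3ccccc3[nH]2)c1)NO`) has not yet been measured. It departs from compound 2 at one point, with (hydroxycarbamoyl)methyl in place of hydroxycarbamoyl on a saturated chain carbon, six bonds along the chain from an oxygen on an aromatic ring. Cut further out, the same difference reads 3-(hydroxycarbamoyl)propyl to 4-(hydroxycarbamoyl)butyl. Within the data shown here, no measured pair shows this change alone, so any forecast is uncertain. The core of compound 2 stays intact, and a small rise is expected, perhaps not much beyond the scatter. The estimated step of a 1.8-fold higher number from compound 2 to compound 3 (0.24 log units; within the scatter) is therefore modest and points toward a weaker inhibitor. The estimate for compound 3 is 35 nM (expected range 10 nM to 130 nM).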

Compound 3, half-maximal inhibitory concentration: 360 nM
The estimate for compound 3 lay 10-fold (1.01 log units) below the measured number; the measured number lies above the stated range.
By their numbers in this assay, from the lowest: compound 2; then compound 3; then compound 1.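

In this assay, replacing hydroxycarbamoyl with (hydroxycarbamoyl)methyl on a saturated chain carbon, six bonds along the chain from an oxygen on an aromatic ring, brings an 18-fold higher number from compound 2 to compound 3 (1.26 log units; beyond the scatter), so the activity of this series is sensitive to chain length at this position, even though the group's counted hydrogen-bond donors and acceptors stay the same. Compound 3 also splits the gap that could not be assigned earlier: with the longer chain held constant, hydrogen in place of 1H-benzimidazol-2-yl on an aromatic carbon gives a 6.4-fold lower number from compound 1 to compound 3 (0.81 log units; beyond the scatter), so this change and the chain change each matter on their own, the chain step being large and the aromatic step modest. Nothing available explains why either change moves the number as it does.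

The compounds shown cover only one step in chain length, so they leave open whether a shorter chain ending in hydroxycarbamoyl would give a lower or a higher number than compound 2. As far as these compounds go, it also remains open whether 1H-benzimidazol-2-yl would cost as much on the chain of compound 2, and how a carboxylic acid would compare with hydroxycarbamoyl at the chain end.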